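Fluoro in place of propyl on the shared benzophenone-type core

The compounds below may be only part of what the source reports. "The series", "measured", "known", "first", "only" and "open" are said of these compounds alone.

Compound 2 `CCCc1cc2c(cc1C(=O)c1ccc(C(=O)O)cc1)C(C)(C)CCC2(C)C` gives in an assay for binding affinity to retinoic acid receptor gamma (Homo sapiens) (a lower number here means tighter binding, a higher number weaker binding), only a limit, > 1000 nM, and not a number. Compound 1 `CCc1cc2c(cc1C(=O)c1ccc(C(=O)O)cc1)C(C)(C)CCC2(C)C` likewise reaches only the limit of this assay, > 1000 nM. Among the compounds with values here, the one measured step, a step that the two limits leave unreadable from compound 1 to compound 2, therefore cannot be read, since both of its ends sit at the limit of > 1000 nM in this assay, at which 2 of the 2 values shown sit. Compound 3 `CC1(C)CCC(C)(C)c2cc(C(=O)c3ccc(C(=O)O)cc3)c(F)cc21` differs from compound 2 by fluoro in place of propyl on an aromatic carbon. Within the data shown here, no measured step bears on this exchange: the propyl of compound 2 and the ethyl of compound 1 both leave the limit of this assay untouched, and the fluoro has no measured counterpart here. The step from compound 2 to compound 3 is thus expected only loosely, as a step that the limit leaves unreadable from compound 2 to compound 3, with a fair chance of staying at the limit. Compound 3 is estimated in this assay at 1500 nM, within a range from 200 nM to 10000 nM.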

Compound 3, dissociation constant: > 1000 nM
Compound 3 ended at the assay's limit; the forecaster's own chance of this, stated with the estimate: 55%; the middle value is on the limit's open side.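

In this assay compound 3 gives > 1000 nM, a limit and not a number. The steps among compound 1, compound 2 and compound 3 cannot be read because each of their ends sits at a limit: the limit of > 1000 nM in this assay, at which 3 of the 3 values shown sit. The compounds shown leave open how tightly each binds and whether ethyl, propyl and fluoro differ at all.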